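Adding a 4-chlorophenyl to the methoxy-type linker of compound 2

This account rests on a few compounds, and the source may have more. Where it says the series, first, only, none or still open, it means among the compounds named here.

Measured compounds:
compound 1, `O=[N+]([O-])c1cccc(COCNc2n[n+]([O-])c3ccccc3[n+]2[O-])c1`: 520 nM
compound 2, `COCNc1n[n+]([O-])c2ccccc2[n+]1[O-]`: 2480 nM

In a functional assay on SMMC-7721 cells (Homo sapiens) for cytotoxicity, read by MTT assay, with a stated time of 72 h (a higher number here means a weaker inhibitor, a lower number a stronger inhibitor), compound 1 gives 520 nM, while compound 2 gives 2480 nM. Compound 2 therefore has the higher of the two numbers; compound 1, which carries a 3-nitrophenyl group on the saturated chain carbon bound to the oxygen, has the lower number, and the gap between them lies beyond the scatter.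

Compound 3, `[O-][n+]1nc(NCOCc2ccc(Cl)cc2)[n+]([O-])c2ccccc21`, has not yet been measured in this assay. It differs from compound 2 in one place: 4-chlorophenyl in place of hydrogen on a saturated chain carbon bound to an oxygen on a saturated carbon. Since compound 1, with an aromatic ring in the same place, gives 520 nM, a comparable gain is expected here. The step of a 3.8-fold lower number from compound 2 to compound 3 (0.58 log units; beyond the scatter) is expected to be a decrease beyond the scatter. Compound 3 is thus estimated at 650 nM, with a range from 250 nM to 1700 nM.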

Compound 3, half-maximal inhibitory concentration: 810 nM
Compound 3: the middle estimate sits 1.2-fold (0.10 log units) below what was measured; the range from low to high includes it.
By their numbers in this assay, from the lowest: compounds 1 and 3 (each within the scatter of the next); then compound 2.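

In this assay the 4-chlorophenyl group, in place of hydrogen on a saturated chain carbon bound to an oxygen on a saturated carbon, gives a 3.1-fold lower number from compound 2 to compound 3 (0.49 log units; beyond the scatter) as a modest step, so this position takes a chlorine-bearing ring as well as a nitro-bearing one. Compound 1 at 520 nM and compound 3 at 810 nM lie within the scatter of each other, so among the compounds shown the lower number does not depend on the 3-nitrophenyl group alone. Nothing shown here accounts for this result.

The compounds shown leave open whether an unsubstituted phenyl ring would already give the same lower number. They also leave open how an amine or a carboxylic acid on the ring, or a longer chain in place of the ring, would read in this assay.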